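Adding a methyl group to a low-toxicity compound

The source may hold more compounds than are shown below. What is called first, only, known or untested is meant among the compounds shown, and "the series" means these compounds.

In an ADME assay on MT4 cells (Homo sapiens) for cytotoxicity, read by MTT assay (on this read-out higher numbers stand for lower toxicity in this test and lower numbers for higher toxicity in this test), compound 2 `COc1ccc(C(=O)CSc2nc(Cc3c(F)cccc3Cl)cc(=O)[nH]2)cc1` gives > 12000 nM, which is a limit of the assay and not a number. Compound 1 `O=C(CSc1nc(Cc2c(F)cccc2Cl)cc(=O)[nH]1)c1ccc(F)cc1` gives > 61000 nM, which is also a limit. The next compound is compound 3 `COc1ccc(C(=O)CSc2nc(Cc3c(F)cccc3Cl)c(C)c(=O)[nH]2)cc1`, which carries methyl in place of hydrogen on an aromatic carbon of a six-membered aromatic ring with 2 nitrogen, ortho to a 2-chloro-6-fluorobenzyl group (methyl in place of hydrogen on an aromatic carbon). Going by the values given here, the only measured step is a step that the two limits leave unreadable from compound 1 to compound 2, which puts methoxy in place of fluoro at another place, so it offers no size to carry over. With so little to go on, no change beyond the scatter is expected in this assay, and a result reported only as a limit is likely. The expected step is a step that the limit leaves unreadable from compound 2 to compound 3. For compound 3 the estimated value is 20000 nM, within an expected range of 6000 nM to 70000 nM.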

Compound 3, half-maximal cytotoxic concentration: > 12000 nM
Compound 3: only a limit was reported (the forecaster's own chance of this, stated with the estimate: 65%); the middle value lies beyond the limit too.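

Going by these compounds alone, compound 2 and compound 3 each carry only a limit and not a number, and no step between them can be read. From the compounds shown here alone, whether methyl in place of hydrogen changes the result in this assay at all, and by how much, stays open.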